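This account rests on a few compounds, and the source may have more. Where it says the series, first, only, none or still open, it means among the compounds named here.

Among the measured compounds shown here, in a functional assay on cells (Leukemia cell, Homo sapiens) for cytotoxicity, with a stated time of 48 h (on this read-out lower numbers stand for stronger inhibition of growth and higher numbers for weaker inhibition of growth), compound 1 `COc1ccc(CN2C(=O)/C(=C\c3cc(OC)c(OC)c(OC)c3)c3ccccc32)cc1` gives 27500 nM, the higher of the two numbers measured so far, so it inhibits growth more weakly than compound 2 `COc1ccc2c(c1)/C(=C\c1cc(OC)c(OC)c(OC)c1)C(=O)N2C`, which gives 7600 nM. Compound 3 `COc1cc(/C=C2\C(=O)N(Cc3ccc(Cl)cc3)c3ccccc32)cc(OC)c1OC` keeps the core of compound 1 and makes a single change chloro in place of methoxy on an aromatic carbon, turning 4-methoxybenzyl into 4-chlorobenzyl. For the measured compounds named here, no measured pair shows what this change does, so no step beyond the scatter is expected. The estimated step is a 1.4-fold lower number from compound 1 to compound 3 (0.14 log units; within the scatter), leaning slightly towards stronger inhibition. Compound 3 is expected at 20000 nM, with a range of 7000 nM to 55000 nM.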

Compound 3, concentration for total growth inhibition: 4900 nM
Estimate against measurement, compound 3: 4.1-fold (0.61 log units) above; the whole stated range lies above it.
By their numbers in this assay, from the lowest: compounds 3 and 2 (each within the scatter of the next); then compound 1.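

Among the compounds shown here, until now, no measured pair showed what this change does. In this assay, turning 4-methoxybenzyl into 4-chlorobenzyl gives a 5.6-fold lower number from compound 1 to compound 3 (0.75 log units; beyond the scatter), so the group at this place, para to a large group, does matter for growth inhibition. Nothing available explains this step. From the compounds shown here alone, what other groups at this place would do stays open, for example fluoro, an amine or a carboxylic acid. Going by these compounds, it is also open whether chloro on another carbon of that ring would give a similar step.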